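The source may report more compounds than this note shows. Statements on the series, on what has been measured and on what is new or still open speak of the compounds shown alone.

Measured in a functional assay on A20 cells (Mus musculus) for inhibition, with stated times of 1 h, 16 h and 24 h; on this read-out lower numbers stand for stronger inhibition and higher numbers for weaker inhibition:
- compound 1 `N#CC1(NC(=O)[C@@H]2C[C@@H](S(=O)(=O)c3ccccc3)C[C@H]2C(=O)N2CC3(COC3)C2)CC1`: 248 nM
- compound 2 `N#CC1(NC(=O)[C@@H]2C[C@@H](S(=O)(=O)c3ccccc3)C[C@H]2C(=O)N2CCCCC2)CC1`: 5 nM
- compound 3 `N#CC1(NC(=O)[C@@H]2C[C@@H](S(=O)(=O)c3ccccc3)C[C@H]2C(=O)N2CCNCC2)CC1`: 1340 nM

Compound 3 has the highest number of the three in this assay, at 1340 nM, so it is the weakest inhibitor measured so far. Compound 4 `N#CC1(NC(=O)[C@@H]2C[C@@H](S(=O)(=O)c3ccccc3)C[C@H]2C(=O)Nc2ccc(F)cc2)CC1` keeps the shared core and alters one group, (4-fluorophenyl)amino in place of piperazin-1-yl on a carbonyl carbon.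

Three measured steps change the group on this carbonyl carbon. The closest comparison is a 270-fold higher number from compound 2 to compound 3 (2.43 log units; beyond the scatter), and it is large. A second step, a 5.4-fold higher number from compound 1 to compound 3 (0.73 log units; beyond the scatter), is modest, while a 50-fold lower number from compound 1 to compound 2 (1.70 log units; beyond the scatter) is large. Together they show that this carbonyl substituent can move the number widely, and that both other groups tried there give lower numbers than compound 3 does. Going by the values given here, none of the measured compounds carries (4-fluorophenyl)amino there, so the size of the change remains uncertain.

Since compound 3 stands at 1340 nM, at the top of the measured range, a large step towards stronger inhibition is expected: a 27-fold lower number from compound 3 to compound 4 (1.43 log units; beyond the scatter). The estimate for compound 4 is 50 nM, with an expected range from 8 nM to 300 nM.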

Compound 4, half-maximal inhibitory concentration: 391 nM
Beside the measured number, compound 4's estimate is 7.8-fold (0.89 log units) below it; the measured number lies above the stated range.
By their numbers in this assay, from the lowest: compound 2; then compounds 1 and 4 (each within the scatter of the next); then compound 3.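

In this assay, going by these compounds alone, (4-fluorophenyl)amino is the only one of the four groups on this carbonyl carbon that brings a six-membered aromatic ring, and it gives a lower number than piperazin-1-yl (a 3.4-fold lower number from compound 3 to compound 4 (0.53 log units; beyond the scatter)), a modest step, while remaining far from the piperidin-1-yl of compound 2 (a 78-fold higher number from compound 2 to compound 4 (1.89 log units; beyond the scatter)), a large step. The new group also cannot be told apart from the group of 7 heavy atoms with its 2 four-membered rings (a 1.6-fold higher number from compound 1 to compound 4 (0.20 log units; within the scatter)), so two groups with very different ring types now give values within the scatter of each other. Compound 2 therefore remains clearly separate from all three other compounds, and neither the aromatic ring nor the amide hydrogen of compound 4 brings this position to the level reached with piperidin-1-yl.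

From the compounds shown here alone, whether an unsubstituted phenylamino group or a morpholin-4-yl ring on this carbonyl carbon would come closer to compound 2 remains open, as does what the fluorine contributes to the value of compound 4. No supporting evidence is available to account for these differences.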